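Urea Analogue of Compound 3 Before Its Measurement

The source may report more compounds than this note shows. Statements on the series, on what has been measured and on what is new or still open speak of the compounds shown alone.

Compound 1 `COc1cc(OC)c2c(=O)cc(C(=O)Nc3ccc(C4CCCCC4)cc3)[nH]c2c1` in a functional assay on SUP-B15 cells (Homo sapiens) for antiproliferative activity, with a stated time of 72 h (on this read-out lower numbers stand for an effect already at smaller amounts and higher numbers for an effect only at larger amounts of compound), gives > 43100 nM, which is a limit of the assay.
Compound 2 `COc1cc(OC)c2c(=O)cc(C(=O)Nc3ccc(S(=O)(=O)c4ccccc4)cc3)[nH]c2c1` in this assay gives > 70600 nM, again a limit of the assay.
Compound 3 `COC(=O)c1cc(=O)c2cc(NC(=O)Nc3ccc(F)c(Cl)c3)ccc2[nH]1` in this assay gives > 12600 nM, also a limit of the assay.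

None of the three measured compounds therefore has a number in this assay; each sits at a limit, as recorded in the limit of > 12600 nM in this assay, at which 1 of the 3 values shown sits, the limit of > 43100 nM in this assay, at which 1 of the 3 values shown sits, and (the limit of > 70600 nM in this assay, at which 1 of the 3 values shown sits). Compound 3 stands at the lowest of these limits, but since all three are limits, nothing can be said about its order against compound 1 or compound 2. Within the data shown here, the only single-point step among the measured compounds, a step that the two limits leave unreadable from compound 1 to compound 2, is unreadable for the same reason.

Compound 4 `COC(=O)c1cc(=O)c2cc(NC(=O)Nc3ccc4c(c3)CCC4)ccc2[nH]1` differs from compound 3 by 2,3-dihydro-1H-inden-5-yl in place of 3-chloro-4-fluorophenyl on an amide-type nitrogen. Among the measured compounds shown here, no measured step touches this change, and the one step that exists could not be sized. Compound 3 itself provides only a limit, so there is no anchor for a direction. The expectation for this assay is that compound 4 will again most probably return a limit rather than a number. Compound 4 is estimated at 20000 nM, with a range from 5000 nM to 100000 nM. The step that the limit leaves unreadable from compound 3 to compound 4 is thus expected to be no step beyond the scatter.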

Compound 4, half-maximal effective concentration: > 24100 nM
Compound 4 ended at the assay's limit; the forecaster's own chance of this, stated with the estimate: 75%; middle value at least 1.2-fold (0.08 log units) away from the limit.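

Compound 4 also ends at a limit of this assay: the limit of > 24100 nM in this assay, at which 1 of the 4 values shown sits. Compound 3 likewise gives only a limit, so the step from compound 3 to compound 4 cannot be read. The compounds shown leave open what number any of the four would carry in this assay, and how they order against one another.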